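Sulfonamide Aryl Swap Against Mitochondrial Malate Dehydrogenase

A few compounds are considered here, and "the series" means these few. Any claim that something is new, unique, unknown or untested is made for them only; others in the source may bear on it.

Compound 1 `O=S(=O)(Nc1ccc(-c2nc3ccccc3o2)cc1)c1cccs1` was tested in an assay on isolated protein for inhibition of malate dehydrogenase, mitochondrial (Sus scrofa), with stated times of 45 min and 30 min; a higher number here means a weaker inhibitor, a lower number a stronger inhibitor. In this assay compound 1 reaches only the limit of > 63000 nM, so no number is known for it. Compound 2 `O=S(=O)(Nc1ccc2oc(-c3ccccc3)nc2c1)c1ccc(O)cc1` was tested as well; in this assay compound 2 likewise reaches only the limit of > 63000 nM. Both compounds thus share (the limit of > 63000 nM in this assay, at which 2 of the 2 values shown sit), and compound 1 stands at that limit with nothing to compare against. Compound 3 `O=S(=O)(Nc1ccc(-c2nc3ccccc3o2)cc1)c1ccc(Cl)cc1` has not yet been measured. It differs from compound 1 by 4-chlorophenyl in place of thiophen-2-yl on a sulfonyl sulfur. Among the measured compounds shown here, no step between measured compounds has been charted, so the size of the change in this assay can only be expected. The step that the limit leaves unreadable from compound 1 to compound 3 is expected to be small, with no direction beyond the scatter. Compound 3 is expected to sit near 80000 nM, between 30000 nM and 300000 nM, most likely reported again only as a limit.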

Compound 3, half-maximal inhibitory concentration: > 63000 nM
Compound 3: a limit, no number (the forecaster's own chance of this, stated with the estimate: 85%); the middle value does not contradict the limit.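

No step can be read between compound 1 and compound 3, because both give only a limit, as does compound 2: the limit of > 63000 nM in this assay, at which 3 of the 3 values shown sit. The compounds shown leave open whether any group on the sulfonyl sulfur would give a number rather than a limit in this assay.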